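The source may hold more compounds than are shown below. What is called first, only, known or untested is meant among the compounds shown, and "the series" means these compounds.

Measured compounds

Compound 1 `CCOC(=O)c1oc2ccc(N(Cc3ccccc3)S(=O)(=O)c3cccc(Br)c3)cc2c1C`: > 40000 nM
Compound 2 `CCOC(=O)c1oc2ccc(N(Cc3ccccc3)S(=O)(=O)c3cccc(Cl)c3)cc2c1C`: > 40000 nM
Compound 3 `Cc1c(C(=O)O)oc2ccc(N(Cc3ccccc3)S(=O)(=O)c3ccc(Br)cc3)cc12`: 20000 nM

Notes. In a functional assay on HCT-116 cells (Homo sapiens) for inhibition, read by MTT assay, with a stated time of 72 h (on this read-out higher numbers stand for weaker inhibition and lower numbers for stronger inhibition), compound 1 reaches only the assay limit of > 40000 nM. Compound 2 likewise sits at the limit of > 40000 nM in this assay. Going by the values given here, compound 3 is the one member of the set with a number, 20000 nM. Between compound 1 and compound 2 the change is chloro in place of bromo on an aromatic carbon, and the step it made, a step that the two limits leave unreadable from compound 1 to compound 2, cannot be sized, because of the limit of > 40000 nM in this assay, at which 2 of the 3 values shown sit.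

The unmeasured compound 4 `Cc1c(C(=O)O)oc2ccc(N(Cc3ccccc3)S(=O)(=O)c3ccc(Cl)cc3)cc12` carries the same kind of change against compound 3: chloro in place of bromo on an aromatic carbon. The two changes are of the same kind, not the same: in compound 1 and compound 2 the exchanged atom sits meta to a large group, in compound 3 and compound 4 it sits para to a large group. The difference between the core of compound 3 and the core of compound 1 is not broken down here.

Expectation. Among the compounds with values here, since the one measured bromo-to-chloro step is unreadable, the only anchor is compound 3 at 20000 nM. Compound 4 is expected to stay close to it, so the step of a 1.3-fold higher number from compound 3 to compound 4 (0.10 log units; within the scatter) is estimated to lie within the usual scatter. The estimate for compound 4 in this assay is 25000 nM, with a fair chance that only a limit is reported.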

Compound 4, half-maximal inhibitory concentration: 33400 nM
The estimate for compound 4 lay 1.3-fold (0.13 log units) below the measured number; the range from low to high includes it.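

In this assay, chloro in place of bromo on the 4-bromophenyl group of compound 3 gives a 1.7-fold higher number from compound 3 to compound 4 (0.22 log units; within the scatter), so on this core, with the halogen para to a large group, the read-out does not separate the two halogens. Going by these compounds alone, this is the only readable step of its kind, since the same kind of change between compound 1 and compound 2 has no size, because both compounds stand at a limit of the assay and not at a number: the limit of > 40000 nM in this assay, at which 2 of the 4 values shown sit. The series therefore gives no test of whether the change carries from one core to the other: the step on the core of compound 3 neither confirms nor contradicts anything on the core of compound 1, and it remains a single observation on a single core.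

From the compounds shown here alone, whether an amine or a nitrile in place of the halogen on the sulfonyl-bound phenyl ring would give a step beyond the scatter stays open, as does the effect of a primary amide in place of the carboxylic acid. Also open, going by these compounds, is how the ethyl ester compares with the carboxylic acid when the halogen and its place on the ring are held fixed.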